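Swapping methylsulfanyl for chloro: what to expect

The compounds below may be only part of what the source reports. "The series", "measured", "known", "first", "only" and "open" are said of these compounds alone.

Values measured in a functional assay on MDA-MB-231 cells (Homo sapiens) for inhibition, read by MTT assay, with a stated time of 48 h; on this read-out higher numbers stand for weaker inhibition and lower numbers for stronger inhibition:
Compound 1 `CCc1ccc(-c2nc3ccccn3c2Sc2ccccc2)cc1`: > 100000 nM (a limit)
Compound 2 `COc1ccc(-c2nc3ccccn3c2Sc2ccccc2)cc1`: > 100000 nM (a limit)
Compound 3 `CSc1ccc(-c2nc3ccccn3c2Sc2ccccc2)cc1`: 23500 nM

Compound 3 is the only one of the three with an actual number, 23500 nM. The other two compounds give no number, and both stand at the limit of > 100000 nM in this assay, at which 2 of the 3 values shown sit. Between them there is a step that the two limits leave unreadable from compound 1 to compound 2, so that pair offers no guidance here.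

Compound 4 `Clc1ccc(-c2nc3ccccn3c2Sc2ccccc2)cc1` differs from compound 3 by a single change: chloro in place of methylsulfanyl on an aromatic carbon. It carries chloro in place of methylsulfanyl on an aromatic carbon, para to a large group.

Among the measured compounds shown here, two measured steps bear on this change. With methylsulfanyl in place of ethyl there is an at least 4.2-fold lower number from compound 1 to compound 3 (0.62 log units; beyond the scatter), and with methylsulfanyl in place of methoxy there is an at least 4.2-fold lower number from compound 2 to compound 3 (0.62 log units; beyond the scatter). Both steps end at methylsulfanyl, so in both the other group goes with the higher number in this assay. Neither step measures chloro itself, which leaves the expectation loose. A move away from methylsulfanyl is expected to go back upward by a modest amount, and it may well reach the limit. The expected change is a 2.3-fold higher number from compound 3 to compound 4 (0.37 log units; beyond the scatter). Compound 4 is estimated at 55000 nM, with an expected range of 18000 nM to 130000 nM.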

Compound 4, half-maximal inhibitory concentration: 24500 nM
For compound 4 the middle estimate is 2.2-fold (0.35 log units) above the measured one; the range from low to high includes it.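

Chloro in place of methylsulfanyl gives a 1.0-fold higher number from compound 3 to compound 4 (0.02 log units; within the scatter) in this assay so at this place, para to a large group, the two groups cannot be told apart on this read-out. The further steps an at least 4.0-fold lower number from compound 2 to compound 4 (0.61 log units; beyond the scatter) and an at least 4.0-fold lower number from compound 1 to compound 4 (0.61 log units; beyond the scatter) show for chloro what the earlier compounds showed only for methylsulfanyl, so among the compounds shown a sulfur atom is not needed for a number under the limit. Compound 1 and compound 2 stay at a limit: (the limit of > 100000 nM in this assay, at which 2 of the 4 values shown sit).

As far as these compounds go, what remains open is whether another halogen such as fluoro or bromo, or an amine or a carboxylic acid, at this place would join compound 3 and compound 4 or stand at a limit like ethyl and methoxy. The compounds shown also give no reason why chloro and methylsulfanyl go together while ethyl and methoxy do not, and they cannot tell how far compound 1 and compound 2 lie past their limit.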